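A few compounds are considered here, and "the series" means these few. Any claim that something is new, unique, unknown or untested is made for them only; others in the source may bear on it.

Compound 1 `O=C1C=CC2(C=C1)OCC(Cc1ccc(F)cc1)C(=O)N2c1ccccc1`: 400 nM
Compound 2 `O=C1C=CC2(C=C1)OCC(Cc1ccc(Br)cc1)C(=O)N2c1ccccc1`: 1380 nM

Both compounds were tested in a functional assay on BV-2 cells (Mus musculus), read by Griess assay, with a stated time of 24 h; a higher number here means a weaker inhibitor, a lower number a stronger inhibitor. Of the two, compound 2 has the higher number, 1380 nM, which makes it the weaker inhibitor of the pair.

The next compound, compound 3 `O=C1C=CC2(C=C1)OCC(Cc1ccc(C(F)(F)F)cc1)C(=O)N2c1ccccc1`, keeps the shared core and changes one group: trifluoromethyl in place of bromo on an aromatic carbon. In words, this is trifluoromethyl in place of bromo on an aromatic carbon, so 4-bromophenyl becomes 4-(trifluoromethyl)phenyl.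

Within the data shown here, only one measured step bears on this change. It involves the same position: a 3.5-fold higher number from compound 1 to compound 2 (0.54 log units; beyond the scatter). That modest step shows that swapping the group here can move the number beyond the scatter. However, a single step sets no rule for a trifluoromethyl group, which has not yet been tested in this series. A modest step is therefore expected again, with only a weak lean towards a lower number and a real chance that it stays within the scatter.

The expected step is a 1.5-fold lower number from compound 2 to compound 3 (0.19 log units; within the scatter). For compound 3, the estimated value is 900 nM, with an expected range of 350 nM to 2300 nM.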

Compound 3, half-maximal inhibitory concentration: 1650 nM
Estimate against measurement, compound 3: 1.8-fold (0.26 log units) below; low and high end bracket the measured number.
By their numbers in this assay, from the lowest: compound 1; then compounds 2 and 3 (each within the scatter of the next).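

In this assay, the estimate leaned towards a change, yet the swap of bromo for trifluoromethyl, which turns 4-bromophenyl into 4-(trifluoromethyl)phenyl, gives a 1.2-fold higher number from compound 2 to compound 3 (0.08 log units; within the scatter) and so does not separate the two groups, even though the entering group holds more heavy atoms than the single bromine it replaces. Measured against fluoro, the same group gives a 4.1-fold higher number from compound 1 to compound 3 (0.62 log units; beyond the scatter), so the gap seen earlier for bromo now appears for a second group, and compound 1, with its fluoro, stands apart as the stronger inhibitor from both of the others in this set of three. The data shown offer no measurement that could explain why fluoro stands apart here.

From the compounds shown here alone, three groups at one place on one shared core cannot show whether the lower number belongs to fluoro alone, so it remains open whether chloro, a methoxy group, a nitrile or an amine would fall with compound 1 or with compounds 2 and 3. Going by these compounds, it also remains open whether the same gap would hold if the phenyl on the ring nitrogen of the core carried a different group.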